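The source may report more compounds than this note shows. Statements on the series, on what has been measured and on what is new or still open speak of the compounds shown alone.

Working notes on a small series read in an assay on HEK293 cells for agonist activity at transient receptor potential cation channel subfamily M member 8 (Homo sapiens), read by fluorescence and calcium flux, with a stated time of 15 min; on this read-out lower numbers stand for an effect already at smaller amounts and higher numbers for an effect only at larger amounts of compound.

Compound 1 `CCN(Cc1cccn1C)C(=O)COc1ccc(C)cc1` gives 21300 nM in this assay, and compound 2 `CCN(Cc1cccs1)C(=O)C[C@H](O)c1ccccc1` gives 52000 nM. Compound 1 thus stands with the lowest of the two numbers at hand; compound 2 sits beyond the scatter of compound 1, at the higher side. Compound 2 differs from compound 1 in more than one place, so no single step is drawn between them; their two values are all that is shown.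

Compound 3 `CCN(C(=O)COc1ccc(C)cc1)C(C)c1cccs1` has not yet been measured in this assay. It differs from compound 1 as follows: 1-(thiophen-2-yl)ethyl in place of (1-methyl-1H-pyrrol-2-yl)methyl on an amide-type nitrogen. The group that leaves and the group that enters are of the same size and carry the same count of donors and acceptors; the hetero atom of the five-membered ring changes, and a methyl is added on the carbon that joins the ring to the amide-type nitrogen.

Among the compounds with values here, no measured pair isolates this change. The step from compound 1 to compound 3 is expected to be small, probably toward a higher number, and within or just beyond the scatter: a 1.3-fold higher number from compound 1 to compound 3 (0.12 log units; within the scatter). For compound 3 the value expected in this assay is 28000 nM, with a range from 9000 nM to 90000 nM.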

Compound 3, half-maximal effective concentration: "not active" (no number reported)
Compound 3: no number reported; no gap can be computed for the estimate.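

Within the data shown here, compound 3 is reported as "not active" with no number, so no step from compound 1 to compound 3 can be read. The compounds shown leave open whether the change of ring hetero atom or the added methyl alone would alter the read-out. Nothing at hand offers an explanation for this result.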